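Dialkylamino in place of pyrrolidinyl on the shared core

This account rests on a few compounds, and the source may have more. Where it says the series, first, only, none or still open, it means among the compounds named here.

Compound 1 `O=C1C(Nc2cccc(Cl)c2)=CC(=O)c2c1nc1n2[C@H]2OC[C@@H](O)[C@H]2OC1` gives 3080 nM in a functional assay on ECa-109 cells for inhibition, with ECa-109 cell line (Homo sapiens) as the target, read by sulforhodamine B assay; a lower number here means a stronger inhibitor, a higher number a weaker inhibitor.
Compound 2 `COc1ccccc1NC1=CC(=O)c2c(nc3n2[C@H]2OC[C@@H](O)[C@H]2OC3)C1=O` gives in this assay only a limit, > 4000 nM.
Compound 3 `O=C1C(N2CCCC2)=CC(=O)c2c1nc1n2[C@H]2OC[C@@H](O)[C@H]2OC1` gives in this assay only a limit, > 16000 nM.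

Compound 3 stands at the limit of > 16000 nM in this assay, at which 1 of the 3 values shown sits, so no number is known for it, and one other value in the set is also a limit. Compound 4 `CCCN(CCC)C1=CC(=O)c2c(nc3n2[C@H]2OC[C@@H](O)[C@H]2OC3)C1=O` differs from compound 3 by dipropylamino in place of pyrrolidin-1-yl on a double-bonded ring carbon. The steps reaching compound 3 are an at least 5.1-fold higher number from compound 1 to compound 3 (0.71 log units; beyond the scatter) and a step that the two limits leave unreadable from compound 2 to compound 3; the readable one points to a weaker number once an arylamino group gives way to pyrrolidin-1-yl. Among the compounds with values here, compound 4 keeps an amine without a hydrogen-bond donor, and no measured step compares two such groups. For compound 4 the expected step is a step that the limit leaves unreadable from compound 3 to compound 4, nothing beyond the scatter. Compound 4 is estimated at 20000 nM, within 8000 nM to 60000 nM, most likely again only a limit.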

Compound 4, half-maximal inhibitory concentration: > 16000 nM
Compound 4 was reported as a limit (the forecaster's own chance of this, stated with the estimate: 70%); the middle value is on the limit's open side.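

Dipropylamino in place of (3-chlorophenyl)amino gives an at least 5.1-fold higher number from compound 1 to compound 4 (0.71 log units; beyond the scatter), so the weaker reading seen with the ring pyrrolidin-1-yl also holds for an open-chain amine at this position. Compound 4 gives only a limit, the same one as compound 3, so neither has a number: the limit of > 16000 nM in this assay, at which 2 of the 4 values shown sit. The steps to compound 4 from compound 2 and from compound 3 cannot be read.

From the compounds shown here alone, whether propylamino or benzylamino on this carbon would give a measurable number stays open. Any order among compound 2, compound 3 and compound 4 also stays open.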